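Swapping the halogen on the sulfonyl-bound ring

A few compounds are considered here, and "the series" means these few. Any claim that something is new, unique, unknown or untested is made for them only; others in the source may bear on it.

Compound 1, `COc1cc(N(Cc2nc3ccccc3[nH]2)S(=O)(=O)c2ccccc2)cc(OC)c1OC`: 25500 nM
Compound 2, `COc1cc(N(Cc2nc3ccccc3[nH]2)S(=O)(=O)c2ccc(Br)cc2)cc(OC)c1OC`: 6890 nM

Going by the values given here, in a functional assay on PC-3 cells (Homo sapiens) for inhibition, read by MTT assay, with a stated time of 48 h (a higher number here means a weaker inhibitor, a lower number a stronger inhibitor), compound 2 holds the lower of the two numbers, and its only neighbour is compound 1, separated by the step of a 3.7-fold lower number from compound 1 to compound 2 (0.57 log units; beyond the scatter). Compound 3, `COc1cc(N(Cc2nc3ccccc3[nH]2)S(=O)(=O)c2ccccc2Cl)cc(OC)c1OC`, differs from compound 2 by 2-chlorophenyl in place of 4-bromophenyl on a sulfonyl sulfur. Among the compounds with values here, that single measured step shows a halogen on this ring lowering the number; no measured step shows whether chlorine in 2-chlorophenyl behaves like bromine in 4-bromophenyl. Compound 3 is therefore expected to land between the two measured values, a step of a 1.7-fold higher number from compound 2 to compound 3 (0.24 log units; within the scatter). The estimated value of compound 3 is 12000 nM, with a range from 4000 nM to 40000 nM.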

Compound 3, half-maximal inhibitory concentration: 34500 nM
Beside the measured number, compound 3's estimate is 2.9-fold (0.46 log units) below it; the measured number falls inside the stated range.
By their numbers in this assay, from the lowest: compound 2; then compounds 1 and 3 (each within the scatter of the next).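

In this assay a halogen on this ring does not by itself lower the number, as 2-chlorophenyl in place of 4-bromophenyl gives a 5.0-fold higher number from compound 2 to compound 3 (0.70 log units; beyond the scatter) and loses the gain seen with bromine. Set against the unsubstituted ring, chloro in place of hydrogen gives a 1.4-fold higher number from compound 1 to compound 3 (0.13 log units; within the scatter) and so leaves compound 3 indistinguishable from compound 1. No measurement offered here accounts for this difference.

The step from compound 2 to compound 3 changes the halogen and its place on the ring together, so their separate contributions remain unresolved. Compounds carrying 4-chlorophenyl or 2-bromophenyl would separate the two.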